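Chalcone-linked pyrazole amides: ring substitution on the styryl arm

This account rests on a few compounds, and the source may have more. Where it says the series, first, only, none or still open, it means among the compounds named here.

The series shares one core, seen in compound 1 `O=C(/C=C/c1ccccc1)c1cccc(NC(=O)c2cc(-c3ccncc3)n[nH]2)c1`, and varies the aromatic ring at the far end of the enone. In a functional assay, read by spectrophotometry, tested at 100 uM (on this read-out higher numbers stand for weaker inhibition and lower numbers for stronger inhibition), compound 1 gives 71500 nM, the highest of the three numbers, though all three sit within the scatter of one another. Compound 2 `COc1ccc(/C=C/C(=O)c2cccc(NC(=O)c3cc(-c4ccncc4)n[nH]3)c2)cc1` gives 54600 nM in this assay, and compound 3 `O=C(/C=C/c1ccc([N+](=O)[O-])cc1)c1cccc(NC(=O)c2cc(-c3ccncc3)n[nH]2)c1` gives 64600 nM. The steps of a 1.3-fold lower number from compound 1 to compound 2 (0.12 log units; within the scatter) and a 1.1-fold lower number from compound 1 to compound 3 (0.04 log units; within the scatter) both change that same ring and both stay within the scatter; the step of a 1.2-fold higher number from compound 2 to compound 3 (0.07 log units; within the scatter) likewise shows no movement.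

Compound 4 `O=C(/C=C/c1ccc(Cl)cc1Cl)c1cccc(NC(=O)c2cc(-c3ccncc3)n[nH]2)c1` is not yet measured. It differs from compound 1 as follows: 2,4-dichlorophenyl in place of phenyl on a double-bonded chain carbon bound to a double-bonded chain carbon. The two measured ring substitutions bear directly on this change, and neither shifted the read-out beyond the scatter. No step beyond the scatter is therefore expected in this assay, with at most a slight drift toward a lower number, in line with compound 2 at 54600 nM. The expected step is a 1.2-fold lower number from compound 1 to compound 4 (0.08 log units; within the scatter). Compound 4 is estimated at 60000 nM, with a range from 25000 nM to 150000 nM.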

Compound 4, half-maximal inhibitory concentration: 80900 nM
Beside the measured number, compound 4's estimate is 1.3-fold (0.13 log units) below it; the measured number falls inside the stated range.
By their numbers in this assay, from the lowest: compounds 2, 3, 1 and 4 (each within the scatter of the next).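

In this assay, the first ring carrying two substituents, 2,4-dichlorophenyl in place of phenyl, gives a 1.1-fold higher number from compound 1 to compound 4 (0.05 log units; within the scatter) and so behaves like the singly substituted rings, with no step beyond the scatter. The comparisons with those rings agree, with a 1.3-fold higher number from compound 3 to compound 4 (0.10 log units; within the scatter) and a 1.5-fold higher number from compound 2 to compound 4 (0.17 log units; within the scatter) as the widest gap among the four compounds, still within the scatter, so this position has now tolerated methoxy, nitro and two chlorine atoms without a measurable shift. No measurement available here accounts for this flat response.

On these data alone, whether an amine, a carboxylic acid or a longer chain on this ring would move the number beyond the scatter remains open. Also open, as far as these compounds go, is whether changes to the shared core, which all four compounds keep, would matter more than changes to this ring.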